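The source may report more compounds than this note shows. Statements on the series, on what has been measured and on what is new or still open speak of the compounds shown alone.

Measured so far in an ADME assay on BJ cells (Homo sapiens) for cytotoxicity, with a stated time of 72 h; on this read-out lower numbers stand for an effect already at smaller amounts and higher numbers for an effect only at larger amounts of compound:
Compound 1 `Nc1cc2c(-n3nc(-c4ccccn4)nc3N)ncnc2cc1Cl`: compound 1 gives 27000 nM.
Compound 2 `COc1cc2ncnc(-n3nc(-c4ccccn4)nc3N)c2cc1[N+](=O)[O-]`: for compound 2 the result is a limit, > 13000 nM.
Compound 3 `COc1cc2ncnc(-n3nc(-c4ccccn4)nc3N)c2cc1N`: for compound 3 the entry reads "not determined" (no result reported), so no result was reported for compound 3.

Compound 3 thus stands without a number of its own; of the values shown, one sits at the limit of > 13000 nM in this assay, at which 1 of the 3 values shown sits, and only compound 1 carries a plain number. Compound 4 `COc1cc2ncnc(-n3nc(-c4ccccn4)nc3N)c2cc1OCc1ccccc1` differs from compound 3 by benzyloxy in place of amino on an aromatic carbon. Going by the values given here, no measured pair that differs in a single place is at hand, so the size of this step in this assay cannot be read from the data; with both measured values weak, a step toward higher numbers, or none beyond the scatter, is expected. Compound 4 is therefore estimated at 20000 nM, between 8000 nM and 50000 nM.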

Compound 4, half-maximal effective concentration: > 27000 nM
Compound 4: only a limit was reported (the forecaster's own chance of this, stated with the estimate: 40%); at least 1.3-fold (0.13 log units) between middle value and limit.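

Going by these compounds alone, compound 2 and compound 4 both carry only limits in this assay, so no step between them can be read. The compounds shown leave open how much benzyloxy, nitro or amino on this aromatic carbon changes the read-out.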